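Notes on the series: step from compound 2 to compound 3

The source may report more compounds than this note shows. Statements on the series, on what has been measured and on what is new or still open speak of the compounds shown alone.

Compound 1 `O=C(CN1C(=O)N/C(=C/c2ccc(Cl)cc2)C1=O)Nc1cccc(C(F)(F)F)c1` was tested in a functional assay on MDA-MB-231 cells (Homo sapiens) for inhibition, read by sulforhodamine B assay, with a stated time of 48 h; on this read-out lower numbers stand for higher toxicity in this test and higher numbers for lower toxicity in this test. In this assay compound 1 gives only a limit, < 100000 nM. Compound 2 `O=C(CN1C(=O)N/C(=C\C=C\c2ccccc2)C1=O)Nc1ccc(Cl)cc1` likewise gives only a limit in this assay, < 100000 nM. Among the measured compounds shown here, compound 2 thus stands where every value so far stands: at a limit of the assay rather than at a number, which is all the two values show (the limit of < 100000 nM in this assay, at which 2 of the 2 values shown sit). Compound 3 `O=C(CN1C(=O)N/C(=C\c2ccc(Cl)cc2)C1=O)Nc1ccc(Cl)cc1` is not yet measured in this assay. It differs from compound 2 by 4-chlorophenyl in place of 2-phenylethenyl on a double-bonded chain carbon bound to a double-bonded ring carbon; the group that enters is the 4-chlorophenyl that compound 1 also carries, and the anilide part of compound 2 is kept. With no numbered step between measured compounds available, no step beyond the scatter is expected from compound 2 to compound 3 in this assay, the expected step being a step that the limit leaves unreadable from compound 2 to compound 3. Compound 3 is accordingly estimated at 50000 nM in this assay, with an expected range from 10000 nM to 100000 nM, and most likely again only a limit.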

Compound 3, concentration lethal to 50% of the cells: < 100000 nM
Compound 3: only a limit was reported (the forecaster's own chance of this, stated with the estimate: 70%); the middle value lies beyond the limit too.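

No step can be read from compound 2 to compound 3, because both values are limits and not numbers: the limit of < 100000 nM in this assay, at which 3 of the 3 values shown sit.

The compounds shown leave open where compound 1, compound 2 and compound 3 would fall as actual numbers in this assay, and whether 4-chlorophenyl and 2-phenylethenyl differ there at all.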